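Aryl variation at the sulfonyl sulfur: cytotoxicity working notes

The source may report more compounds than this note shows. Statements on the series, on what has been measured and on what is new or still open speak of the compounds shown alone.

Measured compounds:
- compound 1 `Cc1cccc(S(=O)(=O)N2CCC(N3CCC(C)CC3)CC2)c1`: in an ADME assay on HCT-116 cells (Homo sapiens) for cytotoxicity, read by CellTiter-Glo, with a stated time of 72 h (on this read-out lower numbers stand for stronger inhibition and higher numbers for weaker inhibition), compound 1 gives only a limit, > 5000 nM
- compound 2 `CC1CCN(C2CCN(S(=O)(=O)c3ccc(Br)c(Cl)c3)CC2)CC1`: in this assay compound 2 likewise gives a limit, > 5000 nM

Both values shown are limits, so the step that the two limits leave unreadable from compound 1 to compound 2 cannot be read. Compound 2 stands at the limit of > 5000 nM in this assay, at which 2 of the 2 values shown sit, with no number to compare against.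

Compound 3 `CC1CCN(C2CCN(S(=O)(=O)c3cc(Cl)cc(Cl)c3)CC2)CC1` differs from compound 2 by 3,5-dichlorophenyl in place of 4-bromo-3-chlorophenyl on a sulfonyl sulfur.

For the measured compounds named here, no measured step bears readably on this change. The expected step is a step that the limit leaves unreadable from compound 2 to compound 3, nothing beyond the scatter. Compound 3 is therefore expected at 10000 nM, within 5000 nM to 40000 nM, most probably reported once more only as a limit.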

Compound 3, half-maximal inhibitory concentration: > 5000 nM
Compound 3: no number, only a limit (the forecaster's own chance of this, stated with the estimate: 85%); the middle value is on the limit's open side.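

No step can be read among compound 1, compound 2 and compound 3, as each gives only a limit: the limit of > 5000 nM in this assay, at which 3 of the 3 values shown sit.

The compounds shown leave open how any of these aryl groups on the sulfonyl sulfur ranks against the others in this assay.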